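A Naphthyl Swap Under Cell Inhibition

The source may report more compounds than this note shows. Statements on the series, on what has been measured and on what is new or still open speak of the compounds shown alone.

Measured so far:
Compound 1 `Cc1cc(Nc2cc(-c3ccccc3)[nH]n2)n2nc(SCc3ccc(Cl)cc3)nc2n1` gives 31800 nM
Compound 3 `Cc1cc(Nc2cc(-c3ccc(Cl)cc3)[nH]n2)n2nc(SCc3ccc(Br)cc3)nc2n1` gives 28200 nM
Compound 2 `CCCCCc1c(C)nc2nc(SCc3ccc(Cl)cc3)nn2c1Nc1cc(-c2ccccc2)[nH]n1` reaches only > 50000 nM, a limit rather than a number

In an ADME assay on GES1 cells (Homo sapiens) for inhibition, read by MTT assay, with a stated time of 72 h (a higher number here means a weaker inhibitor, a lower number a stronger inhibitor), compound 1 gives 31800 nM, the higher of the two numbers. Compound 3 gives 28200 nM, a gap within the scatter, so no order between them can be read. For the measured compounds named here, the only measured step, an at least 1.5-fold higher number from compound 1 to compound 2 (0.19 log units; that floor lies within the scatter), concerns a different place on the shared core. Compound 4 `Cc1cc(Nc2cc(-c3ccccc3)[nH]n2)n2nc(SCc3cccc4ccccc34)nc2n1` differs from compound 1 by naphthalen-1-yl in place of 4-chlorophenyl on a saturated chain carbon bound to a sulfur. Going by the values given here, no measured step touches this position, and compound 3 differs from compound 1 in two places at once, so nothing among the numbers points one way. I therefore expect no step beyond the scatter, a 1.1-fold lower number from compound 1 to compound 4 (0.03 log units; within the scatter). Compound 4 is estimated at 30000 nM, within a range from 12000 nM to 60000 nM.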

Compound 4, half-maximal inhibitory concentration: 36300 nM
Estimate against measurement, compound 4: 1.2-fold (0.08 log units) below; the range from low to high includes it.
By their numbers in this assay, from the lowest: compounds 3, 1 and 4 (each within the scatter of the next). At a limit, above all of these: compound 2.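

In this assay naphthalen-1-yl in place of 4-chlorophenyl on a saturated chain carbon bound to a sulfur gives a 1.1-fold higher number from compound 1 to compound 4 (0.06 log units; within the scatter) and so no readable change. The earlier compounds shown here offered no single step at this position; here, a larger group with a second aromatic ring and no chlorine leaves the number within the scatter. No measurement given here bears on why the number holds.

Still open, on these data alone, is whether a group of another kind at this position, such as an amine or a carboxylic acid, would move the number beyond the scatter.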